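Two Ureas Measured, a Third Awaited

The source may hold more compounds than are shown below. What is called first, only, known or untested is meant among the compounds shown, and "the series" means these compounds.

Compound 1 `Cc1ccc(Nc2cc(NC(=O)Nc3c(Cl)cccc3Cl)ncn2)cc1C` — 92.1%
Compound 2 `COc1cc(Nc2cc(NC(=O)Nc3c(Cl)cccc3Cl)ncn2)cc(OC)c1` — 90%

Compound 1 and compound 2 share a core and differ only in the aryl group on the amine. In a functional assay on PC-9 cells (Homo sapiens) for inhibition, read by MTT assay, with a stated time of 48 h, tested at 10 uM (a lower number here means less inhibition, a higher number more inhibition at the concentration tested (going by the name of the read-out)), compound 1 gives 92.1%, and compound 2 gives 90%; the two numbers lie within the scatter of each other, so compound 1 cannot be placed above or below compound 2 on these data, and both show strong inhibition at the concentration tested.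

Compound 3 `CCc1ccc(Nc2cc(NC(=O)Nc3c(Cl)cccc3Cl)ncn2)cc1` has not yet been measured. It differs from compound 1 by 4-ethylphenyl in place of 3,4-dimethylphenyl on a nitrogen on an aromatic ring. Among the measured compounds shown here, no measured pair isolates such a change, so the expectation rests on the two values shown. Since compound 1 gives 92.1% and compound 2 gives 90%, the step of a number 4.1 percentage points lower from compound 1 to compound 3 (within the scatter) is expected to stay within the scatter, in no clear direction. Compound 3 is estimated at 88%, in a range from 75% to 96%.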

Compound 3, a percentage reported as inhibition, at one concentration (the size of the read-out at that concentration, not a potency): 70.1%
For compound 3 the middle estimate is 17.9 percentage points above the measured one; measured number outside the range, below it.
By their numbers in this assay, from the lowest: compound 3; then compounds 2 and 1 (each within the scatter of the next).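

In this assay, 4-ethylphenyl in place of 3,4-dimethylphenyl on a nitrogen on an aromatic ring gives a number 22 percentage points lower from compound 1 to compound 3 (beyond the scatter), the first step beyond the scatter among these compounds. The two groups have the same count of heavy atoms and the same kind of ring, so this position separates aryl groups that the counted features do not tell apart, which the close pair of compound 1 and compound 2 gave no sign of. No measurement of any property bears on the difference between these two groups here.

The compounds shown leave open whether the ethyl chain itself or the loss of the 3,4-dimethyl pattern accounts for the step. A 4-methylphenyl or a 4-propylphenyl group at the same place would bear on that question.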